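The compounds below may be only part of what the source reports. "The series", "measured", "known", "first", "only" and "open" are said of these compounds alone.

Of the compounds shown here, three sharing one core have so far been tested in a functional assay on KB cells (Homo sapiens) for inhibition, read by sulforhodamine B assay, with a stated time of 48 h, tested at 10 uM; a lower number here means less inhibition of growth, a higher number more inhibition of growth at the concentration tested. Compound 2 `O=C(N/N=C/c1ccc(O)cc1)c1ccc(-c2ccc(F)cc2)o1` gives 11%, the second highest of the three numbers. Its nearest neighbour, compound 3 `Cc1cccc(/C=N/NC(=O)c2ccc(-c3ccccc3[N+](=O)[O-])o2)c1`, gives 10.3%, and the furthest, compound 1 `O=C(N/N=C/c1ccccc1)c1ccc(-c2ccc(Cl)cc2)o1`, gives 17%; both lie within the usual scatter of compound 2, so the three cannot be told apart. Compound 4 `O=C(N/N=C/c1ccccc1Cl)c1ccc(-c2ccc(F)cc2)o1` has not yet been measured. It differs from compound 2 in one place: 2-chlorophenyl in place of 4-hydroxyphenyl on a carbon with a double bond to nitrogen. Going by the values given here, no comparison between measured compounds that differ in a single place is available, so the size of this change cannot be read from them. In this assay the expected change is a number 3 percentage points higher from compound 2 to compound 4 (within the scatter), none beyond the scatter. Compound 4 is estimated at 14%, within 4% to 26%.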

Compound 4, percent growth inhibition at one concentration: 19.3%
For compound 4 the middle estimate is 5.3 percentage points below the measured one; measured number inside the range.
By their numbers in this assay, from the lowest: compounds 3, 2, 1 and 4 (each within the scatter of the next).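

Going by these compounds alone, this is the first comparison at this position in this assay: 2-chlorophenyl in place of 4-hydroxyphenyl on a carbon with a double bond to nitrogen gives a number 8.3 percentage points higher from compound 2 to compound 4 (within the scatter). Losing the hydrogen-bond donor and acceptor of the 4-hydroxyphenyl, with the heavy-atom count unchanged, therefore shifts growth inhibition by no more than the scatter at this one concentration. Nothing at hand explains the size of this step. Going by these compounds, what a 4-aminophenyl or a 4-carboxyphenyl would give in this place stays open, as does a longer chain there.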